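Swapping a thiazole for an oxazole on the amide carbonyl

The compounds below may be only part of what the source reports. "The series", "measured", "known", "first", "only" and "open" are said of these compounds alone.

Among the compounds with values here, compound 2 `CCCCNc1nc(N)nc2c1CN(C(=O)c1csc(C)n1)CC2` gives the higher of the two numbers measured in an assay on HEK293 cells for agonist activity at Toll-like receptor 8 (Homo sapiens), read by a luciferase reporter, with a stated time of 6 h (on this read-out lower numbers stand for an effect already at smaller amounts and higher numbers for an effect only at larger amounts of compound), at 1.8 uM, whereas compound 1 `CCCCNc1nc(N)nc2c1CN(Cc1ccncc1)CC2` gives 0.29 uM; the only measured step, a 6.2-fold higher number from compound 1 to compound 2 (0.79 log units; beyond the scatter), exchanged the whole group on the ring nitrogen. Compound 3 `CCCCNc1nc(N)nc2c1CN(C(=O)c1cocn1)CC2` keeps that carbonyl and alters only the ring attached to it: 1,3-oxazol-4-yl in place of 2-methyl-1,3-thiazol-4-yl on a carbonyl carbon. Within the data shown here, no measured step bears on an exchange of one five-membered aromatic ring for another, so the expected step is a 1.1-fold higher number from compound 2 to compound 3 (0.05 log units; within the scatter), within the scatter. The value of compound 3 is estimated at 2 uM, with a range from 0.8 uM to 5 uM.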

Compound 3, minimum effective concentration: 0.2 uM
Estimate against measurement, compound 3: 10-fold (1.00 log units) above; the whole stated range lies above it.
By their numbers in this assay, from the lowest: compounds 3 and 1 (each within the scatter of the next); then compound 2.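

In this assay the ring on the carbonyl carbon matters: 1,3-oxazol-4-yl in place of 2-methyl-1,3-thiazol-4-yl gives a 9.0-fold lower number from compound 2 to compound 3 (0.95 log units; beyond the scatter) and so removes the loss seen earlier with compound 2. The whole-group exchange gives a 1.5-fold lower number from compound 1 to compound 3 (0.16 log units; within the scatter) and so a carbonyl-linked group can match (pyridin-4-yl)methyl on this nitrogen. Nothing measured here explains the difference between the two rings.

This change replaces the ring and drops its methyl group together. Compounds carrying 1,3-thiazol-4-yl or 2-methyl-1,3-oxazol-4-yl would separate these two parts of the change.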